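Compound 1 to compound 4: a carboxy group on the amide

The source may report more compounds than this note shows. Statements on the series, on what has been measured and on what is new or still open speak of the compounds shown alone.

Measured in a functional assay on MCF7 cells (Homo sapiens) for antiproliferative activity, read by MTT assay, with a stated time of 72 h; on this read-out higher numbers stand for weaker inhibition and lower numbers for stronger inhibition:
- compound 1 `CCN(CC)CCCNC(=O)c1ccc(C(CC)(CC)c2ccc(C#CC(O)(CC)CC)c(C)c2)n1CC`: 17800 nM
- compound 2 `CCn1c(C(=O)NCc2ccc(OC)cc2)ccc1C(CC)(CC)c1ccc(C#CC(O)(CC)CC)c(C)c1`: > 50000 nM (a limit, not a number)
- compound 3 `CCn1c(C(=O)NCC(=O)O)ccc1C(CC)(CC)c1ccc(C#CC(O)(CC)CC)c(C)c1`: 5140 nM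

Only two of these three results are true numbers, and compound 1 holds the higher of them. The nearest result is a 3.5-fold lower number from compound 1 to compound 3 (0.54 log units; beyond the scatter). Compound 2 gives only a limit.

Compound 4 `CCn1c(C(=O)N[C@H](C(=O)O)C(C)C)ccc1C(CC)(CC)c1ccc(C#CC(O)(CC)CC)c(C)c1` has not yet been measured. It keeps the core of compound 1 but carries 1-carboxy-2-methylpropyl in place of 3-(diethylamino)propyl on the amide-type nitrogen: 1-carboxy-2-methylpropyl in place of 3-(diethylamino)propyl on an amide-type nitrogen.

The closest guide is the change to carboxy, which gave a 3.5-fold lower number from compound 1 to compound 3 (0.54 log units; beyond the scatter). Compound 4 also carries a carboxy group on a saturated chain carbon bound to the amide-type nitrogen. The change from the 4-methoxyphenyl group to carboxy points the same way, with an at least 9.7-fold lower number from compound 2 to compound 3 (0.98 log units; beyond the scatter). Not every replacement lowers the number, however, as an at least 2.8-fold higher number from compound 1 to compound 2 (0.44 log units; beyond the scatter) shows. These steps lead to the expectation of a modest drop, and the estimated change in this assay is a 3.0-fold lower number from compound 1 to compound 4 (0.47 log units; beyond the scatter). For compound 4 the estimate is 6000 nM, with an expected range from 2000 nM to 18000 nM.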

Compound 4, half-maximal inhibitory concentration: 13000 nM
For compound 4 the middle estimate is 2.2-fold (0.34 log units) below the measured one; low and high end bracket the measured number.
By their numbers in this assay, from the lowest: compound 3; then compounds 4 and 1 (each within the scatter of the next). At a limit, above all of these: compound 2.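

In this assay, a carboxy group on the amide chain does not by itself set a compound apart from compound 1 (the step reads a 1.4-fold lower number from compound 1 to compound 4 (0.14 log units; within the scatter)), so the lower number of compound 3 does not carry over to every carboxy-bearing chain. What separates the two carboxy compounds is the isopropyl group on the saturated chain carbon bound to the amide-type nitrogen and a carbonyl carbon (the step reads a 2.5-fold higher number from compound 3 to compound 4 (0.40 log units; beyond the scatter)), which shows that this position responds to a substituent on that carbon and not only to the presence of the carboxy group. The step away from 4-methoxybenzyl (it reads an at least 3.8-fold lower number from compound 2 to compound 4 (0.58 log units; beyond the scatter)) gives only a bound, as it starts from a limit and not from a number: the limit of > 50000 nM in this assay, at which 1 of the 4 values shown sits.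

The compounds shown leave open how a methyl or a benzyl group on that same carbon would compare with hydrogen and isopropyl, and what the opposite configuration at the defined stereocentre would give. They also leave open whether a methyl ester or a primary amide in place of the carboxylic acid would keep the number of compound 3 or of compound 4.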